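Cytotoxicity of benzimidazole anilides: from diethylamino to methyl

This account rests on a few compounds, and the source may have more. Where it says the series, first, only, none or still open, it means among the compounds named here.

Measured compounds:
compound 1, `COc1ccc(-c2nc3cc(C(F)(F)F)ccc3[nH]2)c(N)c1`: 5000 nM
compound 2, `CCN(CC)CC(=O)Nc1ccc(-c2nc3cc(C(F)(F)F)ccc3n2C)cc1`: 9000 nM
compound 3, `Nc1ccc(-c2nc3cc(Cl)c(Cl)cc3[nH]2)cc1`: 17000 nM

In an ADME assay on MT4 cells (Homo sapiens) for cytotoxicity, read by MTT assay, with a stated time of 96 h (a lower number here means that less compound is tolerated, a higher number that more compound is tolerated), compound 2 gives 9000 nM, the second highest of the three numbers; its gap to compound 1 and its gap to compound 3 both lie within the scatter, so no order among the three can be read from these values. Compound 4, `CCC(=O)Nc1ccc(-c2nc3cc(C(F)(F)F)ccc3n2C)cc1`, differs from compound 2 in one place: methyl in place of diethylamino on a saturated chain carbon bound to a carbonyl carbon. Among the measured compounds shown here, no step between measured compounds bears on this change, so the expectation rests on compound 2 alone. The step is expected to be small, with no direction beyond the scatter, which the estimate a 1.1-fold higher number from compound 2 to compound 4 (0.05 log units; within the scatter) reflects. Compound 4 is therefore expected to give about 10000 nM, within 4000 nM to 25000 nM.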

Compound 4, half-maximal cytotoxic concentration: 8000 nM
Estimate against measurement, compound 4: 1.3-fold (0.10 log units) above, and the stated range covers the measured number.
By their numbers in this assay, from the lowest: compounds 1, 4, 2 and 3 (each within the scatter of the next, the first and the last beyond it).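

Putting methyl in place of diethylamino on a saturated chain carbon bound to a carbonyl carbon gives a 1.1-fold lower number from compound 2 to compound 4 (0.05 log units; within the scatter) in this assay. Among the compounds shown here, this is the first step that isolates this place, and it shows that the diethylamino group can be exchanged for methyl there without a difference beyond the scatter. Nothing available explains this result.

On these data alone, whether a carboxylic acid, a longer chain or a cyclic amine at this place would also stay within the scatter remains open. A single pair also cannot show whether the same exchange would read alike on another core.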